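Swapping the amine on the second sulfonyl group of compound 1

The source may hold more compounds than are shown below. What is called first, only, known or untested is meant among the compounds shown, and "the series" means these compounds.

Compound 1 `CCOC(=O)[C@@H]1CCCN(S(=O)(=O)c2ccc(S(=O)(=O)N(CC)C(C)C)cc2)C1` gives 1600 nM in a functional assay on BXPC-3 cells (Homo sapiens) for inhibition, read by MTT assay, with a stated time of 7 days (on this read-out lower numbers stand for stronger inhibition and higher numbers for weaker inhibition), the lowest of the three numbers seen. Compound 2 `CCOC(=O)[C@@H]1CCCN(S(=O)(=O)c2ccc(S(=N)(=O)N(CC)CC)cc2)C1` gives 3600 nM, and compound 3 `CCN(CC)S(=O)(=O)c1ccc(S(=O)(=O)N2CCC[C@@H](C(=O)NC3CN(C(=O)NC(C)(C)C)C3)C2)cc1` gives 10100 nM. The step to compound 4 `CCOC(=O)[C@@H]1CCCN(S(=O)(=O)c2ccc(S(=O)(=O)N(C)Cc3ccccc3)cc2)C1` is benzyl(methyl)amino in place of ethyl(isopropyl)amino on a sulfonyl sulfur. Within the data shown here, the only measured step at that same sulfonyl sulfur, a 2.3-fold higher number from compound 1 to compound 2 (0.35 log units; beyond the scatter), shows that exchanging the group there moves the number modestly. Compound 3 changes the other end of the core, so it says nothing direct about this place. A step of similar modest size is therefore expected here, most likely toward a higher number, as a 1.6-fold higher number from compound 1 to compound 4 (0.19 log units; within the scatter). Compound 4 is estimated at 2500 nM, within a range from 900 nM to 7000 nM.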

Compound 4, half-maximal inhibitory concentration: > 30000 nM
Compound 4 was reported as a limit (the forecaster's own chance of this, stated with the estimate: 5%); at least 12-fold (1.07 log units) between middle value and limit.
By their numbers in this assay, from the lowest: compound 1; then compound 2; then compound 3. At a limit, above all of these: compound 4.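

On a sulfonyl sulfur, benzyl(methyl)amino in place of ethyl(isopropyl)amino brings an at least 18-fold higher number from compound 1 to compound 4 (1.27 log units; beyond the scatter), a far larger step than a 2.3-fold higher number from compound 1 to compound 2 (0.35 log units; beyond the scatter). So a single exchange at this position in this assay can do much more than shift the number modestly. Compound 4 stands at a limit, so the full size of its step stays unknown: the limit of > 30000 nM in this assay, at which 1 of the 4 values shown sits.

On these data alone, whether the aromatic ring itself drives this loss stays open. Cyclohexylmethyl(methyl)amino, with a saturated ring in its place, would address that question, and a shorter chain such as diethylamino on the same sulfonyl sulfur would show how the step depends on the amine.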